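The source may report more compounds than this note shows. Statements on the series, on what has been measured and on what is new or still open speak of the compounds shown alone.

Measured so far:
Compound 1 `CC[C@H](CCCc1cccnc1)NC(=O)/C=C/C=C(c1ccc(OC)cc1)c1ccc(OC)cc1`: 120 nM
Compound 2 `COc1ccc(C(=C/C=C/C(=O)NCCCCc2cccnc2)c2ccc(OC)c(OC)c2)cc1OC`: 55 nM

Both values come from an assay (Canis lupus familiaris) for binding affinity to platelet-activating factor receptor (Homo sapiens), read by radioligand binding; on this read-out lower numbers stand for stronger inhibition and higher numbers for weaker inhibition. Compound 2 has the lowest of the two numbers on hand; its nearest neighbour is compound 1, whose number is higher by a gap that lies beyond the scatter. Among the compounds with values here, no pair of measured compounds differs in a single place, so no measured step exists to lean on, and the gap between compound 1 and compound 2 reflects more than one change at once.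

The step under consideration leads from compound 2 to compound 3 `COc1ccc(C(=C/C=C/C(=O)N[C@H](C)CCCc2cccnc2)c2ccc(OC)c(OC)c2)cc1OC`, which is yet to be measured in this assay. The difference is methyl in place of hydrogen on a saturated chain carbon bound to an amide-type nitrogen and a saturated chain carbon. Within the data shown here, compound 1 carries a branch on the corresponding carbon as well, but with a different group and on a different core, so it gives no clean precedent for the effect of this methyl.

Among the measured compounds shown here, with no comparable step recorded, the expected step in this assay from compound 2 to compound 3 is small, in no definite direction, and likely within the scatter: a 1.1-fold higher number from compound 2 to compound 3 (0.04 log units; within the scatter). For compound 3 the estimated value is 60 nM, with a range of 25 nM to 150 nM.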

Compound 3, half-maximal inhibitory concentration: 50 nM
Compound 3: the middle estimate sits 1.2-fold (0.08 log units) above what was measured; low and high end bracket the measured number.
By their numbers in this assay, from the lowest: compounds 3 and 2 (each within the scatter of the next); then compound 1.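

In this assay the series now has its first measured step at this position: methyl in place of hydrogen on a saturated chain carbon bound to an amide-type nitrogen and a saturated chain carbon gives a 1.1-fold lower number from compound 2 to compound 3 (0.04 log units; within the scatter), so the two compounds cannot be told apart on this read-out. Within the data shown here, on the shared core, 1-methyl-4-(pyridin-3-yl)butyl therefore reads the same as 4-(pyridin-3-yl)butyl within the scatter, at least for the single configuration drawn for compound 3; compound 1 could not show this, as it differs from both in more than one place. Nothing available bears on why this methyl leaves the two numbers inseparable.

Open questions remain at the same carbon: whether the opposite configuration of the methyl, a hydroxymethyl or a carboxylic acid would read apart from compound 2 is not settled by these compounds. Also open, from the compounds shown here alone, is whether a methyl at this carbon would give a comparable step on the core of compound 1, or with a longer chain leading to the pyridin-3-yl group.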